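Swapping the ring on the sulfur of a cytotoxic anilide

This account rests on a few compounds, and the source may have more. Where it says the series, first, only, none or still open, it means among the compounds named here.

Measured compounds:
compound 1 `Cn1c(-c2ccc(NC(=O)CSc3nc4ccccc4o3)cc2)nc(-c2ccccc2)c1-c1ccccc1`: 76.3%
compound 2 `Cn1c(-c2ccc(NC(=O)CSC3=NCCS3)cc2)nc(-c2ccccc2)c1-c1ccccc1`: 70%

Both compounds were tested in a functional assay on MCF7 cells (Homo sapiens) for cytotoxicity, read by MTT assay, with a stated time of 24 h, tested at 80 ug/mL; on this read-out higher numbers stand for a stronger effect at the one concentration tested and lower numbers for a weaker effect. Compound 1 gives 76.3% and compound 2 gives 70%; the single measured step, a number 6.3 percentage points lower from compound 1 to compound 2 (within the scatter), is within the scatter, so the two numbers cannot be told apart, and compound 2 stands level with compound 1 on the numbers shown.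

Compound 3 `Cn1ccnc1SCC(=O)Nc1ccc(-c2nc(-c3ccccc3)c(-c3ccccc3)n2C)cc1` has not yet been measured. It differs from compound 2 in one place: a group of 6 heavy atoms (4 carbon, 2 nitrogen; one five-membered aromatic ring with 2 hetero atoms) in place of a group of 5 heavy atoms (3 carbon, 1 nitrogen, 1 sulfur; one five-membered non-aromatic ring with 2 hetero atoms), on a sulfur. For the measured compounds named here, the only step that bears on this change is the one from compound 1 to compound 2, where the group on the sulfur was also exchanged and the read-out barely moved. No step beyond the scatter is therefore expected in this assay for compound 3, in either direction. The estimate for compound 3 is 72%, with a range from 55% to 85%. This estimate means a step of a number 2 percentage points higher from compound 2 to compound 3 (within the scatter), which is expected to stay inside the scatter.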

Compound 3, a percentage reported as activity, at one concentration (the size of the read-out at that concentration, not a potency): 64%
The estimate for compound 3 lay 8 percentage points above the measured number, within the range that was stated.
By their numbers in this assay, from the lowest: compounds 3, 2 and 1 (each within the scatter of the next, the first and the last beyond it).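

In this assay, the group on the sulfur now gives a step that can be read: 1-methyl-1H-imidazol-2-yl in place of 1,3-benzoxazol-2-yl gives a number 12.3 percentage points lower from compound 1 to compound 3 (beyond the scatter). Exchanging the five-membered non-aromatic ring for 1-methyl-1H-imidazol-2-yl gives a number 6 percentage points lower from compound 2 to compound 3 (within the scatter), so only the two aromatic groups can be told apart, while the non-aromatic ring cannot be separated from either. Nothing given here explains the difference between the two aromatic groups.

As far as these compounds go, all three groups on this sulfur are rings, so it remains open how an open-chain group, such as an ethyl group or a short chain ending in a carboxylic acid or an amine, would read. For the compounds shown here, with only one concentration per compound, these numbers tell only of a stronger or weaker effect at that concentration.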